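Series notes: butylation of a long-chain amino scaffold

A few compounds are considered here, and "the series" means these few. Any claim that something is new, unique, unknown or untested is made for them only; others in the source may bear on it.

Compound 1 `CCCCCCCCCCCCCCC(N)CO`, compound 2 `CCCCCCCCCCCCCCC(CO)NCCCC` and compound 3 `CCCCCCCCCCCCCCC(NCCCC)C(=O)O` have been run in an ADME assay on cells (Splenocyte, Mus musculus, strain BALB/c) for cytotoxicity, read by MTT assay, tested at 10 ug/mL; on this read-out lower numbers stand for a weaker effect and higher numbers for a stronger effect at the one concentration tested. Compound 1 gives 20.2%, compound 2 gives 16.4%, and compound 3 gives 5.1%, the lowest of the three. The change from compound 1 to compound 2 is butyl in place of hydrogen on an amine nitrogen; it produced a number 3.8 percentage points lower from compound 1 to compound 2 (within the scatter). From compound 2 to compound 3 the change is carboxy in place of hydroxymethyl on a saturated chain carbon bound to an amine nitrogen and a saturated chain carbon, giving a number 11.3 percentage points lower from compound 2 to compound 3 (beyond the scatter). The difference between the core of compound 1 and the core of compound 3 is not broken down here.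

Compound 4 `CCCCCCCCCCCCCCC(C(=O)O)N(CCCC)CCCC` has not yet been measured in this assay. It differs from compound 3 by butyl in place of hydrogen on an amine nitrogen. This is the same kind of change as that from compound 1 to compound 2, not the same: in compound 1 the amine nitrogen has a saturated chain carbon as its other neighbour, whereas in compound 3 its other neighbours are a saturated chain carbon and a saturated chain carbon. Among the compounds with values here, the one measured instance of this change, a number 3.8 percentage points lower from compound 1 to compound 2 (within the scatter), lay within the scatter. On that basis a step of similar size is expected, a number 0.6 percentage points lower from compound 3 to compound 4 (within the scatter). Compound 3 already sits at 5.1%, which leaves little room for a large downward move. Compound 4 is estimated at 4.5%, with a range from 0% to 13%.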

Compound 4, a percentage reported as activity, at one concentration (the size of the read-out at that concentration, not a potency): 12.5%
Estimate against measurement, compound 4: 8 percentage points below; low and high end bracket the measured number.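

In this assay, butyl in place of hydrogen on an amine nitrogen gives a number 7.4 percentage points higher from compound 3 to compound 4 (within the scatter), and the comparison with the earlier instance of this change finds no difference that can be read: the same change on two cores in this assay, a number 3.8 percentage points lower (within the scatter) from compound 1 to compound 2 and a number 7.4 percentage points higher (within the scatter) from compound 3 to compound 4, 11.2 percentage points apart, within the scatter of two such steps.

As far as these two cores go, the change carries over from the core of compound 1 to the core of compound 3 without a step that stands out from the scatter on either core, so the opposite signs of the two steps cannot be taken as a reversal. This does not show that the change is inert or that it will transfer to other cores, as the comparison rests on one step per core, each read at a single concentration.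

On these data alone, it remains open whether a methyl or a hexyl group on the amine nitrogen, or a methyl ester or primary amide in place of the carboxy group, would give a step beyond the scatter. As far as these compounds go, a shorter or longer main chain on the shared scaffold is also open, as is the behaviour of the butyl change at other concentrations.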